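The compounds below may be only part of what the source reports. "The series", "measured", "known", "first", "only" and "open" are said of these compounds alone.

Measured so far in a functional assay on DU-145 cells (Homo sapiens) for cytotoxicity, read by MTT assay; on this read-out higher numbers stand for weaker inhibition and lower numbers for stronger inhibition:
compound 1, `CC(=O)OCCO[C@H](CC=C(C)C)C1=CC(=O)c2c(O)ccc(O)c2C1=O` — 15500 nM
compound 2, `CC(C)=CC[C@@H](OC[C@H](C)O)C1=CC(=O)c2c(O)ccc(O)c2C1=O` — 24500 nM
compound 3, `CC(C)=CC[C@@H](OC(=O)C1CCCCO1)C1=CC(=O)c2c(O)ccc(O)c2C1=O` — 24700 nM

Compound 3 gives the highest of the three numbers, but its gaps to the others are within the scatter (a 1.6-fold higher number from compound 1 to compound 3 (0.20 log units; within the scatter); a 1.0-fold higher number from compound 2 to compound 3 (0.00 log units; within the scatter)), so no ordering among the three is claimed. Compound 4 is `CCCCC(CC(=O)O[C@H](CC=C(C)C)C1=CC(=O)c2c(O)ccc(O)c2C1=O)OC(C)=O`. Its difference from compound 3: 2-acetoxyhexyl in place of oxan-2-yl on a carbonyl carbon. For the measured compounds named here, the steps that bear on it are those that exchanged the group on an oxygen on a saturated carbon: a 1.6-fold higher number from compound 1 to compound 3 (0.20 log units; within the scatter), a 1.0-fold higher number from compound 2 to compound 3 (0.00 log units; within the scatter) and a 1.6-fold higher number from compound 1 to compound 2 (0.20 log units; within the scatter), none beyond the scatter. Nothing in the series suggests this position moves the numbers, so no step beyond the scatter is expected in this assay for compound 4. The estimate for compound 4 is 24000 nM, range 11000 nM to 52000 nM. For compound 4 the expected step is a 1.0-fold lower number from compound 3 to compound 4 (0.01 log units; within the scatter).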

Compound 4, half-maximal inhibitory concentration: 67700 nM
Compound 4: the middle estimate sits 2.8-fold (0.45 log units) below what was measured; measured number outside the range, above it.
By their numbers in this assay, from the lowest: compounds 1, 2 and 3 (each within the scatter of the next); then compound 4.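

Putting 2-acetoxyhexyl in place of oxan-2-yl on the carbonyl carbon gives a 2.7-fold higher number from compound 3 to compound 4 (0.44 log units; beyond the scatter) in this assay, a modest shift toward weaker inhibition. For the compounds shown here, this is the first step beyond the scatter, so the group on this carbonyl carbon can move the number, whereas the earlier exchanges all stayed within the scatter. No measurement shown here explains the step.

Loss of the ring, the longer chain and the acetoxy group change together in this one step, and their separate contributions stay open. Also open, on these data alone, is how a plain hexyl chain, or a chain ending in an amine or a carboxylic acid, would read here.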